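The compounds below may be only part of what the source reports. "The series", "measured", "known", "first", "only" and "open" are said of these compounds alone.

Measured in a functional assay on HCT-116 cells (Homo sapiens), read by MTT assay, with a stated time of 72 h; a lower number here means a stronger inhibitor, a higher number a weaker inhibitor:
Compound 1 `Nc1nc(N)c2c(-c3cc4ccccc4o3)cn([C@@H]3O[C@H](CO)[C@@H](O)[C@H]3O)c2n1`: 14000 nM
Compound 2 `COc1nc(N)nc2c1c(-c1cccs1)cn2[C@@H]1O[C@H](CO)[C@@H](O)[C@H]1O`: > 20000 nM

Compound 2 has only a limit, > 20000 nM, and no number. Compound 3 `COc1nc(N)nc2c1c(-c1cc3ccccc3o1)cn2[C@@H]1O[C@H](CO)[C@@H](O)[C@H]1O` keeps the core of compound 2 but has 1-benzofuran-2-yl in place of thiophen-2-yl on an aromatic carbon. Among the measured compounds shown here, no measured pair isolates this change in this assay. Compound 1, which also carries 1-benzofuran-2-yl on a core of its own, gives 14000 nM, so only a small gain in strength is expected. The expected size of the change is an at least 1.3-fold lower number from compound 2 to compound 3 (0.12 log units; that floor lies within the scatter). For compound 3 the estimate is 15000 nM, with an expected range of 5000 nM to 30000 nM.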

Compound 3, half-maximal inhibitory concentration: > 20000 nM
Compound 3: only a limit was reported; the forecaster's own chance of this, stated with the estimate: 40%; middle value at least 1.3-fold (0.12 log units) away from the limit.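

In this assay, compound 3, with 1-benzofuran-2-yl in place of thiophen-2-yl, also gives only a limit, and the step from compound 2 cannot be read because both compounds sit at the same limit: the limit of > 20000 nM in this assay, at which 2 of the 3 values shown sit. The new compound does supply the first readable step, an at least 1.4-fold higher number from compound 1 to compound 3 (0.15 log units; that floor lies within the scatter), for methoxy in place of amino on an aromatic carbon with 1-benzofuran-2-yl kept. That step therefore shows no clear effect of this change.

From the compounds shown here alone, it remains open whether an ethoxy group or a hydroxyl group on that carbon, or a pyridine ring in place of 1-benzofuran-2-yl, would give a number rather than a limit.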